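A Chain-Bound Group Exchanged on Compound 1, Awaiting Compound 3

The source may hold more compounds than are shown below. What is called first, only, known or untested is meant among the compounds shown, and "the series" means these compounds.

Compound 1 `CCC/N=C(/NC#N)NCCCCn1nc(-c2ccccc2)ccc1=O` was examined in a functional assay on the whole organism (stomach) with Rattus norvegicus as the target (on this read-out lower numbers stand for an effect already at smaller amounts and higher numbers for an effect only at larger amounts of compound), together with one close relative. In this assay compound 1 gives > 100 mg/kg and this is a limit of the assay rather than a number. Compound 2 `C/N=C(/NC#N)N(C)CCCCn1nc(-c2ccccc2)ccc1=O` was tested in the same way. In this assay compound 2 gives > 100 mg/kg which is again a limit and not a number. Both results therefore sit at the limit of > 100 mg/kg in this assay, at which 2 of the 2 values shown sit, so that compound 1 stands at the edge of what the assay reports, and nothing on these numbers sets it apart from compound 2.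

Compound 3 `O=c1ccc(-c2ccccc2)nn1CCCCNC(=S)Nc1ccccc1` has not yet been measured. It differs from compound 1 by a group of 9 heavy atoms (7 carbon, 1 nitrogen, 1 sulfur; one six-membered aromatic ring of carbon only) in place of a group of 8 heavy atoms (5 carbon, 3 nitrogen; no ring), on an amine nitrogen on the chain. For the measured compounds named here, since neither compound 1 nor compound 2 returned a number, there is no measured step to lean on, and the entering group has no counterpart among the measured compounds. The step of an at least 1.2-fold lower number from compound 1 to compound 3 (0.09 log units; that floor lies within the scatter) is expected to be small, most likely none beyond the usual scatter, tilting toward a lower dose if anything. Compound 3 is estimated at 80 mg/kg within a range from 20 mg/kg to 300 mg/kg and it may well again return only a limit.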

Compound 3, dose for half-maximal effect: > 100 mg/kg
Compound 3: only a limit was reported; the forecaster's own chance of this, stated with the estimate: 65%; at least 1.2-fold (0.09 log units) between middle value and limit.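

No step from compound 1 to compound 3 can be read, since both results are limits of the assay and not numbers: the limit of > 100 mg/kg in this assay, at which 3 of the 3 values shown sit.

The compounds shown leave open whether exchanging the group on the amine nitrogen shifts the response at all in this assay, as compound 1, compound 2 and compound 3 offer no number to compare.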